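The source may hold more compounds than are shown below. What is called first, only, known or untested is meant among the compounds shown, and "the series" means these compounds.

The measured compounds in an assay for inhibition of beta-glucuronidase (Bos taurus), read by spectrophotometry, with a stated time of 30 min; on this read-out higher numbers stand for weaker inhibition and lower numbers for stronger inhibition:
Compound 1, `Cc1ncc([N+](=O)[O-])n1CCOC(=O)c1ccc(Cl)c(Cl)c1`, gives 3600 nM.
Compound 2, `Cc1ncc([N+](=O)[O-])n1CCOC(=O)c1cccc(F)c1`, gives 8100 nM.

Going by the values given here, compound 2 stands with the higher of the two numbers in this assay; its only neighbour is compound 1, whose value of 3600 nM lies a step below it that goes beyond the usual scatter. Among the compounds with values here, no pair among the measured compounds differs in a single place, so the change leading to compound 3 has no measured precedent. Compound 3, `Cc1ncc([N+](=O)[O-])n1CCOC(=O)c1cccnc1`, carries pyridin-3-yl in place of 3-fluorophenyl on a carbonyl carbon. With two data points, neither of which isolates this change, its direction cannot be read from them. A step of modest size is expected, a 1.2-fold higher number from compound 2 to compound 3 (0.09 log units; within the scatter), likely not beyond the scatter, since compound 2 already stands at 8100 nM and nothing in the pair speaks for a change of this kind. Compound 3 is therefore estimated at 10000 nM, within a range from 3000 nM to 35000 nM.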

Compound 3, half-maximal inhibitory concentration: 32600 nM
For compound 3 the middle estimate is 3.3-fold (0.51 log units) below the measured one, within the range that was stated.
By their numbers in this assay, from the lowest: compound 1; then compound 2; then compound 3.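

Going by these compounds alone, measured in this assay, pyridin-3-yl in place of 3-fluorophenyl on a carbonyl carbon gives a 4.0-fold higher number from compound 2 to compound 3 (0.60 log units; beyond the scatter), the first step that isolates a single change. It shows that the read-out responds to the group at this place: exchanging one six-membered aromatic ring for another, with a fluorine leaving and a ring nitrogen entering, moves the number towards weaker inhibition by more than the usual scatter. No measurement at hand accounts for this step.

The compounds shown leave open whether a plain phenyl here would stand nearer compound 2 or compound 3, and so whether the step follows the loss of the fluorine or the entry of the ring nitrogen. They also leave open how pyridin-4-yl, or a phenyl carrying an amine or a carboxylic acid, would read at this place.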